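Repositioning the uracil on a weak antiproliferative scaffold

The source may hold more compounds than are shown below. What is called first, only, known or untested is meant among the compounds shown, and "the series" means these compounds.

Three compounds share a fused bicyclic core carrying a nitrophenylsulfonyl group and a heterocycle on a saturated ring carbon. Compound 1 `O=[N+]([O-])c1ccc(S(=O)(=O)N2CC(n3cnc4ncnc(Cl)c43)OCc3ccccc32)cc1` gives 1220 nM in a functional assay on MCF7 cells (Homo sapiens) for antiproliferative activity; on this read-out lower numbers stand for stronger inhibition and higher numbers for weaker inhibition. Compound 2 `O=c1cc[nH]c(=O)n1C1CN(S(=O)(=O)c2ccccc2[N+](=O)[O-])c2ccccc2CO1` gives 50900 nM, and compound 3 `O=c1cc[nH]c(=O)n1C1CN(S(=O)(=O)c2ccc([N+](=O)[O-])cc2)c2ccccc2CO1` gives 44300 nM. Compound 3 thus stands second highest of the three numbers: its nearest neighbour is compound 2, with a 1.1-fold lower number from compound 2 to compound 3 (0.06 log units; within the scatter), while compound 1 lies furthest away, with a 36-fold higher number from compound 1 to compound 3 (1.56 log units; beyond the scatter).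

Compound 4 `O=c1ccn(C2CN(S(=O)(=O)c3ccc([N+](=O)[O-])cc3)c3ccccc3CO2)c(=O)[nH]1` has the same atoms as compound 3, joined differently: a group of 8 heavy atoms (4 carbon, 2 nitrogen, 2 oxygen; one six-membered aromatic ring with 2 hetero atoms) in place of a group of 8 heavy atoms (4 carbon, 2 nitrogen, 2 oxygen; one six-membered aromatic ring with 2 hetero atoms), on a saturated ring carbon. Neither measured step bears directly on this change. The step from compound 1 to compound 3 shows that replacing the heterocycle wholesale moves the number a great deal, but here the heterocycle keeps its name-free composition and only its attachment shifts; the step from compound 2 to compound 3 shows that moving the nitro group changes nothing beyond the scatter. Among the compounds with values here, with no precedent for this rearrangement, compound 4 is expected to stay close to compound 3, with a step of a 1.5-fold lower number from compound 3 to compound 4 (0.17 log units; within the scatter) that may fall within the scatter. Compound 4 is therefore estimated at 30000 nM, within a range of 8000 nM to 120000 nM.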

Compound 4, half-maximal inhibitory concentration: 39800 nM
Compound 4: middle estimate off by 1.3-fold (0.12 log units), on the low side; the range from low to high includes it.
By their numbers in this assay, from the lowest: compound 1; then compounds 4, 3 and 2 (each within the scatter of the next).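

In this assay, the way the six-membered aromatic ring with 2 hetero atoms is joined to the saturated ring carbon next to the ring oxygen makes no difference that can be told from the scatter (a 1.1-fold lower number from compound 3 to compound 4 (0.05 log units; within the scatter)). The large gap to the group of compound 1 persists with this second attachment (a 33-fold higher number from compound 1 to compound 4 (1.51 log units; beyond the scatter)), so that gap does not depend on one particular way of joining the smaller group, and among these compounds the number follows the identity of the group rather than its connection. No measurement shown here accounts for the two attachments reading alike or for the larger group standing apart.

The compounds shown leave open which feature of the larger group in compound 1 goes with its lower number, the chlorine or the five-membered aromatic ring; the two groups differ in both at once. They also leave open whether an amine or a methoxy group in place of that chlorine would hold the number of compound 1, and whether moving the nitro group, which changed nothing beyond the scatter with the smaller group, would do the same with the larger one.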